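Methylating the ring amine of compound 1

The compounds below may be only part of what the source reports. "The series", "measured", "known", "first", "only" and "open" are said of these compounds alone.

Among the compounds with values here, compound 1 `CNc1nc(NCc2ccc(C(=O)NC3CCN(Cc4ccc(F)cc4)CC3)cc2)c2cc(C)ccc2n1` is the only member of the set with a numeric reading: in a functional assay on SW480 cells (Homo sapiens) for inhibition, read by luminescence and resazurin assay, with a stated time of 3 days (a lower number here means a stronger inhibitor, a higher number a weaker inhibitor), compound 1 gives 1300 nM. Compound 2 `CCCNc1nc2ccccc2c(NCc2ccc(NC(=O)c3ccc(F)cc3)cc2)c1C#N` returns only a limit in this assay, namely > 20000 nM. Compound 3 `CNc1nc2ccccc2c(NCc2ccc(NC(=O)c3ccc(F)cc3)cc2)c1C#N` likewise returns only a limit in this assay, namely > 20000 nM. Within the data shown here, the single measured step between neighbours, a step that the two limits leave unreadable from compound 2 to compound 3, stays unreadable because the limit of > 20000 nM in this assay, at which 2 of the 3 values shown sit, leaves no number on either side of it.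

Compound 4 `Cc1ccc2nc(N(C)C)nc(NCc3ccc(C(=O)NC4CCN(Cc5ccc(F)cc5)CC4)cc3)c2c1` differs from compound 1 by methyl in place of hydrogen on a nitrogen on an aromatic ring; read one bond further out, methylamino becomes dimethylamino. Among the measured compounds shown here, no measured step touches this position, and the one step present, between compound 2 and compound 3, concerns a different change and gives no size anyway. The expectation for compound 4 therefore rests on compound 1 alone, with nothing in the set to argue for a move beyond the usual scatter in either direction. The step from compound 1 to compound 4 is expected at a 1.5-fold higher number from compound 1 to compound 4 (0.19 log units; within the scatter), which is no more than the scatter allows. Compound 4 is estimated at 2000 nM, with a range from 700 nM to 6000 nM.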

Compound 4, half-maximal inhibitory concentration: 1100 nM
The estimate for compound 4 lay 1.8-fold (0.26 log units) above the measured number; measured number inside the range.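

In this assay, within the data shown here, the first readable step at this position is a 1.2-fold lower number from compound 1 to compound 4 (0.07 log units; within the scatter), so methylamino to dimethylamino leaves the number unchanged within the scatter. Earlier compounds said nothing about this nitrogen: the hydrogen on it can give way to methyl on the core of compound 1 with no readable loss in this read-out, although a single pair shows this for that core alone. No measured property available here bears on this step, and no cause can be given for it.

Still open, as far as these compounds go, is whether this nitrogen would tolerate more than methyl, for example a longer chain such as propyl, a ring such as morpholine, or a chain ending in an amine or a carboxylic acid, and whether any of these would move the number beyond the scatter in either direction. The only other step in the set, from compound 2 to compound 3, cannot be read, so the series offers no second reading of a change on a ring amine, because both of its ends are limits of the assay: the limit of > 20000 nM in this assay, at which 2 of the 4 values shown sit.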